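This account rests on a few compounds, and the source may have more. Where it says the series, first, only, none or still open, it means among the compounds named here.

Measured in a functional assay on MOLT-4 cells (Homo sapiens) for cytotoxicity, read by CCK-8 assay, with a stated time of 24 h; a higher number here means a weaker inhibitor, a lower number a stronger inhibitor:
compound 1 `C=CC(=O)N1C(=O)CC(c2ccc(C)cc2)Sc2ccccc21`: 87600 nM
compound 2 `C=CC(=O)N1C(=O)CC(C)Sc2ccccc21`: 730000 nM
compound 3 `C=CC(=O)N1C(=O)CC(c2cccs2)Sc2ccccc21`: 557000 nM

Compound 1, which carries a 4-methylphenyl group, is the strongest of the three. Compound 3 sits well away from it, with a 6.4-fold higher number from compound 1 to compound 3 (0.80 log units; beyond the scatter). Against the methyl compound, however, there is no clear difference, with a 1.3-fold lower number from compound 2 to compound 3 (0.12 log units; within the scatter).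

The next compound, compound 4 `C=CC(=O)N1C(=O)CC(c2ccccc2)Sc2ccccc21`, keeps the shared core and changes one group: phenyl in place of thiophen-2-yl on a saturated ring carbon, next to the ring sulfur (phenyl in place of thiophen-2-yl on a saturated ring carbon).

Within the data shown here, two measured steps bear most directly on this change. Leaving the 4-methylphenyl group of compound 1 gave an 8.3-fold higher number from compound 1 to compound 2 (0.92 log units; beyond the scatter) with methyl and a 6.4-fold higher number from compound 1 to compound 3 (0.80 log units; beyond the scatter) with thiophen-2-yl, both modest. The phenyl group of compound 4 is the group of compound 1 without its methyl, so the value of compound 1, 87600 nM, is the closest guide. Among the measured compounds shown here, no measured pair shows what that methyl contributes, so compound 4 may not come all the way down to compound 1. In this assay, a modest move to a lower number is therefore expected, and the expected step is a 2.7-fold lower number from compound 3 to compound 4 (0.42 log units; beyond the scatter). For compound 4 the estimated value is 210000 nM, with an expected range of 80000 nM to 550000 nM.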

Compound 4, half-maximal inhibitory concentration: 85900 nM
Compound 4: middle estimate off by 2.4-fold (0.39 log units), on the high side, within the range that was stated.
By their numbers in this assay, from the lowest: compounds 4 and 1 (each within the scatter of the next); then compounds 3 and 2 (each within the scatter of the next).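

In this assay, phenyl in place of thiophen-2-yl gives a 6.5-fold lower number from compound 3 to compound 4 (0.81 log units; beyond the scatter), and phenyl in place of methyl gives an 8.5-fold lower number from compound 2 to compound 4 (0.93 log units; beyond the scatter), so at this saturated ring carbon, next to the ring sulfur, the two aromatic rings are clearly not interchangeable. Hydrogen in place of methyl on the aromatic carbon gives a 1.0-fold lower number from compound 1 to compound 4 (0.01 log units; within the scatter), a difference within the scatter, which shows that the methyl of the 4-methylphenyl group is not needed to hold this level. Among these four compounds, the six-membered aromatic ring of carbon only, with or without that methyl, thus separates from both thiophen-2-yl and methyl, and having just any aromatic ring at this position is not enough, as compound 3 shows. Nothing available here explains why the phenyl and thiophen-2-yl rings differ in this way.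

The compounds shown leave open whether other groups on the phenyl ring, such as a methoxy group, a chlorine or a carboxylic acid, would move the number in either direction. They also leave open what part the vinylcarbonyl group plays, since all four compounds carry it.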